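The compounds below may be only part of what the source reports. "The series", "measured", "known", "first", "only" and "open" are said of these compounds alone.

Measured compounds in a functional assay on A549 cells (Homo sapiens) for cytotoxicity, read by MTT assay, with a stated time of 6 days; on this read-out higher numbers stand for an effect only at larger amounts of compound and lower numbers for an effect already at smaller amounts:

Compound 1, `COC(=O)c1c(-c2ccc(OC)cc2)oc2ccccc2c1=O`: in this assay compound 1 gives > 25 ug/mL, a limit of the assay and not a number.
Compound 2, `COC(=O)c1c(-c2ccc([N+](=O)[O-])cc2)oc2ccccc2c1=O`: compound 2 gives > 25 ug/mL, again a limit.
Compound 3, `COC(=O)c1c(-c2ccc(O)cc2)oc2ccccc2c1=O`: compound 3 gives > 25 ug/mL, also a limit.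

All three values sit at the same limit, (the limit of > 25 ug/mL in this assay, at which 3 of the 3 values shown sit), so the steps a step that the two limits leave unreadable from compound 1 to compound 2, a step that the two limits leave unreadable from compound 1 to compound 3 and a step that the two limits leave unreadable from compound 2 to compound 3 are unreadable in size. The change from compound 1 to compound 3 is hydrogen in place of methyl on an oxygen on an aromatic ring; the step it made, a step that the two limits leave unreadable from compound 1 to compound 3, cannot be read.

Compound 4, `O=C(O)c1c(-c2ccc([N+](=O)[O-])cc2)oc2ccccc2c1=O`, is not yet measured. It arises from compound 2 by hydrogen in place of methyl on an oxygen next to a carbonyl group. The two cores differ by nitro in place of methoxy on an aromatic carbon. The place differs: in compound 3 the oxygen sits on an aromatic ring with an aromatic carbon as neighbour, in compound 4 next to a carbonyl group with a carbonyl carbon as neighbour, so this is the same kind of change, not the same.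

With every measured value a limit, the step that the limit leaves unreadable from compound 2 to compound 4 from compound 2 to compound 4 is expected to be small and most likely unreadable again. Compound 4 is estimated at 40 ug/mL, from 15 ug/mL to 120 ug/mL, probably reported as a limit.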

Compound 4, concentration for half-maximal effect: > 25 ug/mL
Compound 4: a limit, no number; the forecaster's own chance of this, stated with the estimate: 80%; the middle value lies beyond the limit too.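

Compound 4, like compound 2, is a limit and not a number, so no new step can be read: the limit of > 25 ug/mL in this assay, at which 4 of the 4 values shown sit. The compounds shown leave open whether any change on the shared core gives a readable value.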